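The compounds below may be only part of what the source reports. "The series", "measured", "known", "first", "only" and "open" are said of these compounds alone.

Measured compounds:
- compound 1 `Cn1c(SCC(=O)N2CCC[C@H]2C(=O)Nc2ccccc2-n2cccc2)nc2ccccc21`: 9 nM
- compound 2 `O=C(Nc1ccccc1-c1ccccc1)[C@@H]1CCCN1C(=O)CSc1nc2ccccc2[nH]1`: 10 nM
- compound 3 `O=C(Nc1ccc(-c2ccccc2)cc1)[C@@H]1CCCN1C(=O)CSc1nc2ccccc2[nH]1`: 2300 nM

In an assay on CHO cells for displacement of a labelled ligand from Orexin/Hypocretin receptor type 1 (Homo sapiens) (on this read-out lower numbers stand for stronger inhibition and higher numbers for weaker inhibition), compound 1 gives 9 nM, and compound 2 gives 10 nM, a number within the usual scatter of compound 1's. Compound 3 gives 2300 nM, a far higher number than compound 1, beyond the scatter. The unmeasured compound 4 `O=C(Nc1ccccc1-n1cccc1)[C@@H]1CCCN1C(=O)CCc1nc2ccccc2[nH]1` differs from compound 1 in one place: (1H-benzimidazol-2-yl)methyl in place of (1-methyl-1H-benzimidazol-2-yl)sulfanyl on a saturated chain carbon bound to a carbonyl carbon. Going by the values given here, no measured pair shows this change on its own, so its effect is not known from these data. From the compounds shown here alone, compound 1 and compound 2 suggest that the methyl on the ring nitrogen matters little, but the sulfur-to-carbon exchange is untested. A modest weakening is expected, with the step from compound 1 to compound 4 estimated at a 2.8-fold higher number from compound 1 to compound 4 (0.44 log units; beyond the scatter). Compound 4 is therefore expected to give about 25 nM, in the range 5 nM to 150 nM.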

Compound 4, inhibition constant: 130 nM
Estimate against measurement, compound 4: 5.2-fold (0.72 log units) below, within the range that was stated.
By their numbers in this assay, from the lowest: compounds 1 and 2 (each within the scatter of the next); then compound 4; then compound 3.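

Going by these compounds alone, the swap of (1-methyl-1H-benzimidazol-2-yl)sulfanyl for (1H-benzimidazol-2-yl)methyl is the first single-place change here, and in this assay it gives a 14-fold higher number from compound 1 to compound 4 (1.16 log units; beyond the scatter). This shows that binding is sensitive to the group at this place, even though the two groups are nearly the same size. Nothing available explains the loss. From the compounds shown here alone, the swap removes the sulfur and the ring methyl together, so their separate shares remain unknown. (1-Methyl-1H-benzimidazol-2-yl)methyl, or a link through an oxygen atom, would help to separate them.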